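The compounds below may be only part of what the source reports. "The series", "measured", "known", "first", "only" and "open" are said of these compounds alone.

Measured compounds, values in an assay for inhibition of cytokinin dehydrogenase 2 (Arabidopsis thaliana); on this read-out higher numbers stand for weaker inhibition and lower numbers for stronger inhibition:

compound 1, `COc1cccc(Nc2nc(Cl)nc3[nH]cnc23)c1` — compound 1 gives 1900 nM
compound 2, `Clc1cccc(Nc2nc(Cl)nc3[nH]cnc23)c1` — compound 2 gives 3900 nM
compound 3, `COc1ccc(Nc2nc(Cl)nc3[nH]cnc23)cc1` — compound 3 is reported only as a limit, > 100000 nM

Compound 1 holds the lowest of the two numbers given in this assay. Going by the values given here, the single measured step between compounds that differ in one place is a 2.1-fold higher number from compound 1 to compound 2 (0.31 log units; beyond the scatter), a chloro in place of methoxy on an aromatic carbon of the anilino ring. The value for compound 3 is a limit of the assay and not a number, as stated in the limit of > 100000 nM in this assay, at which 1 of the 3 values shown sits.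

Compound 4, `COc1cccc(Nc2nc([N+](=O)[O-])nc3[nH]cnc23)c1`, differs from compound 1 by nitro in place of chloro on an aromatic carbon. Among the compounds with values here, no measured step touches this position of the shared core; the one measured step changes the anilino ring, so its size cannot be carried over to this change. The expectation for compound 4 is therefore a step of a 1.3-fold higher number from compound 1 to compound 4 (0.12 log units; within the scatter), within the scatter, with a wide range to either side. Compound 4 is estimated at 2500 nM, between 600 nM and 12000 nM.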

Compound 4, half-maximal inhibitory concentration: 14000 nM
The estimate for compound 4 lay 5.6-fold (0.75 log units) below the measured number; the whole stated range lies below it.
By their numbers in this assay, from the lowest: compound 1; then compound 2; then compound 4. At a limit, above all of these: compound 3.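

In this assay, the position between two ring nitrogen atoms on the shared core now has a measured step: a 7.4-fold higher number from compound 1 to compound 4 (0.87 log units; beyond the scatter), with nitro in place of chloro. The earlier step, a 2.1-fold higher number from compound 1 to compound 2 (0.31 log units; beyond the scatter), concerned only the anilino ring, whereas this result shows that the number also responds to a change on the core, and that of the two groups seen at this position chloro gives the lower number. Nothing in the data shown accounts for this step.

As far as these compounds go, whether an amine, a methyl group or plain hydrogen at this position would give a number lower than that seen with chloro remains open. Also open, from the compounds shown here alone, is whether the step from chloro to nitro would keep its size with the anilino ring of compound 2.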